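A few compounds are considered here, and "the series" means these few. Any claim that something is new, unique, unknown or untested is made for them only; others in the source may bear on it.

Measured so far:
- compound 1, `COc1c(Cl)cccc1-n1c(C)cc(C(=O)O)c1C`: 800 nM
- compound 2, `Cc1cc(C(=O)O)c(C)n1-c1ccccc1Cl`: 2300 nM

Series notes. In an assay on cells for inhibition of Palmitoleoyl-protein carboxylesterase NOTUM variant C330S (Homo sapiens), read by fluorescence, with a stated time of 40 min (a lower number here means a stronger inhibitor, a higher number a weaker inhibitor), compound 1 gives 800 nM, and compound 2 gives 2300 nM. Compound 2 therefore carries the higher of the two numbers shown so far; the gap between compound 1 and compound 2 is beyond the scatter, so of the two, compound 2 is the weaker inhibitor on the evidence available.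

The next compound, compound 3 `Cc1cc(C(=O)O)c(C)n1-c1cccc(Cl)c1Cl`, is reached from compound 2 by a single change: chloro in place of hydrogen on an aromatic carbon, placed ortho to a chloro group and meta to a large group. Among the compounds with values here, no pair of measured compounds isolates this exact change, so no measured step can be carried over. Compound 1, which also carries a chloro on that ring, stands lower than compound 2 in this assay, but compound 1 differs from compound 3 in the group neighbouring that chloro, so the comparison is only loose.

Expectation: a small step in this assay, if any, more likely toward a lower number than a higher one, and possibly none beyond the scatter. For compound 3 the estimate in this assay is 1200 nM (range 400 nM to 3500 nM), which amounts to an expected step of a 1.9-fold lower number from compound 2 to compound 3 (0.28 log units; within the scatter).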

Compound 3, half-maximal inhibitory concentration: 220 nM
The estimate for compound 3 lay 5.5-fold (0.74 log units) above the measured number; measured number outside the range, below it.
By their numbers in this assay, from the lowest: compound 3; then compound 1; then compound 2.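

In this assay, chloro in place of hydrogen on an aromatic carbon, ortho to a chloro group and meta to a large group, gives a 10-fold lower number from compound 2 to compound 3 (1.02 log units; beyond the scatter) and is a large step, so this carbon of the ring is far from indifferent to what it carries. A separate single change, chloro in place of methoxy on an aromatic carbon, gives a 3.6-fold lower number from compound 1 to compound 3 (0.56 log units; beyond the scatter) and is a modest step, which shows that the methoxy of compound 1 is matched and exceeded by a second chloro. Compound 3, with its two chloro groups, is therefore the strongest inhibitor of the three, its steps to both others lying beyond the scatter.

Still open, on these data alone, is whether the large step belongs to chloro itself or would also come with bromo, methyl or trifluoromethyl on that same carbon. Also open, as far as these compounds go, is whether it would survive on a changed core, for instance with an amide or a tetrazole in place of the carboxylic acid. No supporting measurement bears on why these steps take the size they do.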